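A few compounds are considered here, and "the series" means these few. Any claim that something is new, unique, unknown or untested is made for them only; others in the source may bear on it.

The compounds measured so far in an ADME assay on Vero cells (Chlorocebus sabaeus) for cytotoxicity; a higher number here means that more compound is tolerated, a lower number that less compound is tolerated:

Compound 1 `CO/N=C(\C)CCN1CCN(c2nc(=O)c3cc(C(F)(F)F)cc([N+](=O)[O-])c3s2)CC1` gives > 64 ug/mL, which is a limit of the assay.
Compound 2 `CCO/N=C(\C)CCN1CCN(c2nc(=O)c3cc(C(F)(F)F)cc([N+](=O)[O-])c3s2)CC1` gives > 64 ug/mL, also a limit.
Compound 3 `CON=C1CCC(CN2CCN(c3nc(=O)c4cc(C(F)(F)F)cc([N+](=O)[O-])c4s3)C[C@H]2C)CC1` gives > 64 ug/mL, again a limit.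

Compound 4 `CCON=C1CCC(CN2CCN(c3nc(=O)c4cc(C(F)(F)F)cc([N+](=O)[O-])c4s3)C[C@H]2C)CC1` has not yet been measured in this assay. It differs from compound 3 by methyl in place of hydrogen on a saturated chain carbon bound to an oxygen on an unsaturated carbon. The same change is made from compound 1 to compound 2, namely (methyl in place of hydrogen on a saturated chain carbon bound to an oxygen on an unsaturated carbon), and in this assay that step, a step that the two limits leave unreadable from compound 1 to compound 2, cannot be read: both of its values are limits. The difference between the core of compound 1 and the core of compound 3 is not broken down here. All that the measurements show is the limit of > 64 ug/mL in this assay, at which 3 of the 3 values shown sit.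

For compound 4 the step from its parent is expected to be a step that the limit leaves unreadable from compound 3 to compound 4, which rests on compound 3 sitting at the limit > 64 ug/mL. It also rests on compound 2, which after the same change sits at the limit > 64 ug/mL. Compound 4 is therefore expected to give about 80 ug/mL, within 40 ug/mL to 200 ug/mL, and most probably the assay will again report only a limit.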

Compound 4, half-maximal cytotoxic concentration: > 64 ug/mL
Compound 4 gave a limit, no number; the forecaster's own chance of this, stated with the estimate: 85%; the middle value is on the limit's open side.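

Compound 4 gives > 64 ug/mL in this assay and this is a limit of the assay. With limits at both ends, the step from compound 3 to compound 4 cannot be read. The compounds shown leave open whether methoxy to ethoxy changes cytotoxicity at all and at what concentration any compound becomes cytotoxic, for the data show only this: the limit of > 64 ug/mL in this assay, at which 4 of the 4 values shown sit.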